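Sulfonyl aryl swap on the shared core: compound 3 to compound 4

The source may hold more compounds than are shown below. What is called first, only, known or untested is meant among the compounds shown, and "the series" means these compounds.

Working notes on a small set sharing one core. Compound 1 `Cc1ccc(S(=O)(=O)c2cnc3cc(Cl)ccc3c2N2CCC(C)CC2)cc1F` gives 85% in an assay on isolated protein for displacement of a labelled ligand from metabotropic glutamate receptor 5 (Homo sapiens), with a stated time of 60 min, tested at 1 uM; on this read-out higher numbers stand for more inhibition at the one concentration tested (going by the name of the read-out) and lower numbers for less inhibition. Compound 2 `Cc1ccc(S(=O)(=O)c2cnc3cc(F)ccc3c2N2CCC(C)CC2)cc1Cl` gives 93% in this assay. Compound 3 `CC1CCN(c2c(S(=O)(=O)c3ccc(Cl)cc3)cnc3cc(Cl)ccc23)CC1` gives 91% in this assay; it stands second highest of the three, with compound 2 nearest and compound 1 furthest, both gaps within the scatter. Within the data shown here, the one measured step that changes the group on the sulfonyl sulfur is a number 6 percentage points higher from compound 1 to compound 3 (within the scatter), within the scatter.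

Compound 4 `Cc1ccc(S(=O)(=O)c2cnc3cc(Cl)ccc3c2N2CCC(C)CC2)cc1Cl` is not yet measured in this assay. The change from compound 3 is 3-chloro-4-methylphenyl in place of 4-chlorophenyl on a sulfonyl sulfur. Compound 2 carries the same 3-chloro-4-methylphenyl on a different core and gives 93%. On the same core as compound 3, but with a 3-fluoro-4-methylphenyl on the sulfonyl sulfur, compound 1 gives 85%. No change at the sulfonyl sulfur in this set has moved the read-out beyond the scatter, so the step is expected to be a number 1 percentage points lower from compound 3 to compound 4 (within the scatter), no clear direction. Compound 4 is therefore estimated at 90%, with a range of 80% to 97%.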

Compound 4, a percentage reported as inhibition, at one concentration (the size of the read-out at that concentration, not a potency): 89%
Compound 4: middle estimate off by 1 percentage points, on the high side; the range from low to high includes it.
By their numbers in this assay, from the lowest: compounds 1, 4, 3 and 2 (each within the scatter of the next).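

In this assay, the swap on the sulfonyl sulfur gives a number 2 percentage points lower from compound 3 to compound 4 (within the scatter), so 3-chloro-4-methylphenyl and 4-chlorophenyl cannot be told apart at this position on the shared core. Chloro in place of fluoro on an aromatic carbon gives a number 4 percentage points lower from compound 2 to compound 4 (within the scatter) and a number 4 percentage points higher from compound 1 to compound 4 (within the scatter), so neither of these two exchanges separates the compounds either. Nothing available here explains why these changes leave the read-out within the scatter.

Whether an amine or a carboxylic acid on the aryl group at the sulfonyl sulfur would move the read-out remains open, as the aryl groups shown carry only chloro, fluoro or methyl. With a single tested concentration, these compounds also leave any difference in potency unresolved.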